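The compounds below may be only part of what the source reports. "The series", "measured", "known", "first", "only" and "open" are said of these compounds alone.

In a functional assay on B16 cells (Mus musculus) (on this read-out lower numbers stand for stronger inhibition and higher numbers for weaker inhibition), compound 1 `CC(=O)OCC1O[C@@H](Nc2ccc(C(=O)O)cc2)[C@@H](OC(C)=O)C(OC(C)=O)[C@@H]1OC(C)=O` gives 18 uM and compound 2 `CC(=O)OCC1O[C@@H](Nc2ccc(C(=O)O)cc2)[C@@H](OC(C)=O)C(OC(C)=O)[C@H]1OC(C)=O` gives 49 uM, so compound 2 stands at the higher number of the two, on the side of weaker inhibition. Going by the values given here, the only measured step is a 2.7-fold higher number from compound 1 to compound 2 (0.43 log units; beyond the scatter). What separates the pair is the fact that one of compounds 1 and 2 is drawn with a defined configuration and the other without, at the place where they differ.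

Compound 3 `CC(=O)OC1[C@@H](OC(C)=O)C(C)O[C@@H](Nc2ccc(C(=O)O)cc2)[C@H]1OC(C)=O` departs from compound 2 in a different way: hydrogen in place of acetoxy on a saturated chain carbon bound to a saturated ring carbon. Here hydrogen takes the place of acetoxy on a saturated chain carbon bound to a saturated ring carbon, so that acetoxymethyl becomes methyl. Among the compounds with values here, no measured step touches this group. Within the data shown here, the one measured step therefore serves only as a rough gauge of how far numbers move. It was modest and sets no direction for the new change. A step of similar or smaller size is expected in this assay, with either direction open. The expected step is a 1.2-fold lower number from compound 2 to compound 3 (0.09 log units; within the scatter). For compound 3 the estimated value is 40 uM, with an expected range of 15 uM to 100 uM.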

Compound 3, concentration for 50% inhibition: 20 uM
The estimate for compound 3 lay 2.0-fold (0.30 log units) above the measured number; the measured number falls inside the stated range.
By their numbers in this assay, from the lowest: compounds 1 and 3 (each within the scatter of the next); then compound 2.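

In this assay, the series now has a step that changes a substituent rather than a drawn configuration: going from acetoxymethyl to methyl gives a 2.5-fold lower number from compound 2 to compound 3 (0.39 log units; beyond the scatter) and moves the number towards stronger inhibition. The acetoxy group on this saturated chain carbon is therefore not needed to keep the level of compound 2, and its loss has a direction that a 2.7-fold higher number from compound 1 to compound 2 (0.43 log units; beyond the scatter) could not indicate for this place, though both steps are modest. Nothing available bears on why this replacement gives this step.

The compounds shown leave open whether a hydroxymethyl, an aminomethyl or a longer chain at this place would read closer to methyl or to acetoxymethyl, so one step does not yet define a trend for this group. They also leave open whether hydrogen in place of acetoxy would give a step of similar size and the same direction with the ring-carbon configuration drawn in compound 1.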